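Oxime Replaced by Acetyl: Expected Paw Edema Inhibition

The source may hold more compounds than are shown below. What is called first, only, known or untested is meant among the compounds shown, and "the series" means these compounds.

In a functional assay on the whole organism (strain albino) for inhibition, with Rattus norvegicus as the target, read by paw edema, with stated times of 30 min and 2 h, at a dose of 0.28 mmol/kg by the oral route (a higher number here means more inhibition at the dose given (going by the name of the read-out), a lower number less inhibition), the three measured compounds read as follows:
compound 1 `COc1cc(-c2nnc(SCC(=O)Nc3ccc(/C(C)=N/O)cc3)n2-c2ccccc2)cc(OC)c1OC` gives 62%;
compound 2 `C/C(=N\O)c1ccc(NC(=O)CSc2nnc(-c3ccccc3)n2-c2ccccc2)cc1` gives 52%;
compound 3 `CCn1c(SCC(=O)Nc2ccc(/C(C)=N/O)cc2)nnc1-c1ccccc1` gives 57%.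

Compound 2 carries the smallest of these three numbers, yet the step of a number 10 percentage points lower from compound 1 to compound 2 (within the scatter) and the step of a number 5 percentage points higher from compound 2 to compound 3 (within the scatter) both stay within the usual scatter, so no real difference between the three is established.

Compound 4 `CC(=O)c1ccc(NC(=O)CSc2nnc(-c3ccccc3)n2-c2ccccc2)cc1` is the unmeasured partner of compound 2. The change is a group of 3 heavy atoms (2 carbon, 1 oxygen; no ring) in place of a group of 4 heavy atoms (2 carbon, 1 nitrogen, 1 oxygen; no ring), on an aromatic carbon. Both measured steps altered the other end of the shared core, so neither bears directly on this exchange. With nothing pointing either way, the step of a number 2 percentage points lower from compound 2 to compound 4 (within the scatter) is expected to remain within the scatter. Compound 4 is therefore estimated at 50%, within 35% to 65%.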

Compound 4, a percentage reported as inhibition, in the whole organism at one dose (the size of the read-out at that dose, not a potency): 49%
Compound 4: the middle estimate sits 1 percentage points above what was measured; low and high end bracket the measured number.
By their numbers in this assay, from the lowest: compounds 4, 2, 3 and 1 (each within the scatter of the next, the first and the last beyond it).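

In this assay the exchange of oxime for acetyl gives a number 3 percentage points lower from compound 2 to compound 4 (within the scatter) and so establishes no real difference at this position, the first place changed at this end of the shared core. The hydrogen-bond donor that leaves with the oxime is therefore not shown to be needed for this reading at the dose given. No measurement here offers an explanation for this result. On these data alone, it remains open whether an amine or a carboxylic acid in this place would read differently. Also open, as far as these compounds go, is whether acetyl would read alike on the cores of compound 1 and compound 3.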